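Chain length and monoamine oxidase B inhibition

The source may hold more compounds than are shown below. What is called first, only, known or untested is meant among the compounds shown, and "the series" means these compounds.

Of the compounds shown here, three built on one shared core have been tested in an assay on cells for inhibition of Amine oxidase [flavin-containing] B (Homo sapiens), read by fluorescence, with a stated time of 30 min; a higher number here means a weaker inhibitor, a lower number a stronger inhibitor. Compound 1 `O=C(CCc1cccc(OCCCCN2CCc3ccccc3C2)c1)c1ccccc1O` gives 26700 nM. Compound 2 `O=C(/C=C/c1cccc(OCCCCCCN2CCc3ccccc3C2)c1)c1ccccc1O` gives 6700 nM. Compound 3 `O=C(/C=C/c1cccc(OCCCCN2CCc3ccccc3C2)c1)c1ccccc1O` gives 5300 nM, the lowest of the three numbers; the number for compound 2 lies within the usual scatter of it, while the number for compound 1 lies well beyond that scatter. Compound 2 and compound 3 share the same unsaturated link to the ketone and differ only in the chain carrying the saturated ring, yet their two values are indistinguishable within the scatter.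

Compound 4 `O=C(/C=C/c1cccc(OCCCCCN2CCc3ccccc3C2)c1)c1ccccc1O` has not yet been measured. It differs from compound 3 by (1,2,3,4-tetrahydroisoquinolin-2-yl)methyl in place of 1,2,3,4-tetrahydroisoquinolin-2-yl on a saturated chain carbon, four bonds along the chain from an oxygen on an aromatic ring, so its chain sits between those of compound 3 and compound 2. For the measured compounds named here, no directly comparable step is available for this change. Since the values of compound 2 and compound 3 in this assay sit so close together, compound 4 is expected to give a number of the same order, with no step beyond the scatter in either direction, as a 1.0-fold higher number from compound 3 to compound 4 (0.02 log units; within the scatter) expresses. Compound 4 is therefore estimated at 5500 nM in this assay, with a plausible range from 2500 nM to 12000 nM.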

Compound 4, half-maximal inhibitory concentration: 4800 nM
Estimate against measurement, compound 4: 1.1-fold (0.06 log units) above, and the stated range covers the measured number.
By their numbers in this assay, from the lowest: compounds 4, 3 and 2 (each within the scatter of the next); then compound 1.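

In this assay, placing (1,2,3,4-tetrahydroisoquinolin-2-yl)methyl in place of 1,2,3,4-tetrahydroisoquinolin-2-yl on a saturated chain carbon, four bonds along the chain from an oxygen on an aromatic ring, gives a 1.1-fold lower number from compound 3 to compound 4 (0.04 log units; within the scatter), so the assay cannot tell these two chains apart. The opposite exchange, made on a saturated chain carbon five bonds along the chain from an oxygen on an aromatic ring, gives a 1.4-fold lower number from compound 2 to compound 4 (0.14 log units; within the scatter), and this pair cannot be told apart either. Compound 2 and compound 3 alone could have concealed a sharp rise or fall at the chain length in compound 4, but these steps show none, so the chain length is a flat stretch across these three compounds.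

Nothing measured here explains why these chains give such similar numbers. From the compounds shown here alone, it remains open whether a much shorter chain, a longer chain, or a piperidine ring in place of 1,2,3,4-tetrahydroisoquinolin-2-yl would move the number beyond the scatter, and how the saturated link of compound 1, at 26700 nM, would behave on the chain of compound 4.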